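A few compounds are considered here, and "the series" means these few. Any claim that something is new, unique, unknown or untested is made for them only; others in the source may bear on it.

Of the compounds shown here, two built on a shared core have been tested so far in an ADME assay on microsomes from liver (Mus musculus) for metabolic stability, with a stated time of 10 min, tested at 0.5 uM; a higher number here means that more of the compound is left, a lower number that less of the compound is left. Compound 1 `Cc1noc(C)c1[C@@H]1C[C@@](C)(c2ccc(F)cc2)N=C(N)S1` gives 90%, and compound 2 `Cc1noc(-c2ccccc2)c1[C@@H]1C[C@@](C)(c2ccc(F)cc2F)N=C(N)S1` gives 6%. Compound 2 therefore holds the lower of the two numbers, and its gap to compound 1 lies beyond the usual scatter of repeated measurements.

Compound 3 `Cc1noc(C(F)F)c1[C@@H]1C[C@@](C)(c2ccc(F)cc2F)N=C(N)S1` departs from compound 2 in one place: difluoromethyl in place of phenyl on an aromatic carbon. In plain terms, difluoromethyl stands in place of phenyl on an aromatic carbon. Within the data shown here, no measured pair of compounds isolates this change, so any forecast is loose. Among the measured compounds shown here, the one guide is that compound 1, which has no phenyl in that place, reaches 90%, and this suggests that compound 2 at 6% need not mark the level of compound 3. A clear rise is expected, though probably not all the way to the level of compound 1. The estimated change is upward and beyond the scatter, a number 44 percentage points higher from compound 2 to compound 3 (beyond the scatter). For compound 3 the expected value in this assay is 50%, with an estimated range from 22% to 80%.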

Compound 3, percent of the compound remaining: 59%
Compound 3: the middle estimate sits 9 percentage points below what was measured; measured number inside the range.
By their numbers in this assay, from the lowest: compound 2; then compound 3; then compound 1.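

In this assay, difluoromethyl in place of phenyl on an aromatic carbon, next to the ring oxygen, gives a number 53 percentage points higher from compound 2 to compound 3 (beyond the scatter) with nothing else in the molecule altered. Among these compounds, this is the first pair in which this place can be read on its own, and it shows that the group held there can by itself move the amount of compound left by a large margin: here, a group of 3 heavy atoms with no ring replaces a group of 6 heavy atoms with a six-membered aromatic ring. No measurement in hand explains why the number rises.

The compounds shown leave open whether the rise follows from losing the phenyl or from bringing in difluoromethyl, and how other groups in this place, such as trifluoromethyl, a nitrile or an amine, would read. Compound 1 carries methyl in this place but also differs from compound 3 in a second place, so that pair does not isolate the effect of methyl.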